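The source may hold more compounds than are shown below. What is called first, only, known or untested is meant among the compounds shown, and "the series" means these compounds.

Compound 2 `O=S(=O)(NCCCCNCc1ccc(Br)cc1)c1cc(C(F)(F)F)cc(C(F)(F)F)c1` and compound 1 `CC(C)(C)c1ccc(CNCCCNS(=O)(=O)c2cc(C(F)(F)F)cc(C(F)(F)F)c2)cc1` were both run in a functional assay on MIA PaCa-2 cells (Homo sapiens) for inhibition, read by MTT assay, with a stated time of 72 h; on this read-out lower numbers stand for stronger inhibition of growth and higher numbers for weaker inhibition of growth. Compound 2 gives 2100 nM, and compound 1 gives 2300 nM; the two numbers lie within the scatter of each other, so neither can be ranked against the other. Compound 3 `O=S(=O)(NCCCNCc1ccc(Cl)c(Cl)c1)c1cc(C(F)(F)F)cc(C(F)(F)F)c1` is an untested analogue of compound 2 carrying ((3,4-dichlorobenzyl)amino in place of ((4-bromobenzyl)amino)methyl on a saturated chain carbon, three bonds along the chain from a sulfonamide nitrogen), that is, (3,4-dichlorobenzyl)amino in place of ((4-bromobenzyl)amino)methyl on a saturated chain carbon, three bonds along the chain from a sulfonamide nitrogen. Among the compounds with values here, with no step of this kind among the measured compounds, no change beyond the scatter is expected in this assay, and the estimated step is a 1.1-fold lower number from compound 2 to compound 3 (0.02 log units; within the scatter). Compound 3 is therefore estimated at 2000 nM, with a range from 800 nM to 5000 nM.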

Compound 3, concentration for 50% growth inhibition: 2700 nM
The estimate for compound 3 lay 1.4-fold (0.13 log units) below the measured number; the range from low to high includes it.
By their numbers in this assay, from the lowest: compounds 2, 1 and 3 (each within the scatter of the next).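

In this assay, replacing ((4-bromobenzyl)amino)methyl with (3,4-dichlorobenzyl)amino gives a 1.3-fold higher number from compound 2 to compound 3 (0.11 log units; within the scatter), while 3,4-dichlorophenyl in place of 4-(tert-butyl)phenyl gives a 1.2-fold higher number from compound 1 to compound 3 (0.07 log units; within the scatter). Within the data shown here, these are the first steps that can be read here, and neither change separates the compounds beyond the scatter, so both exchanges are tolerated on this read-out. Nothing further is available to explain this result. Still open, as far as these compounds go, is whether a 4-methoxybenzyl group, or an amide in place of the amine, would move the number beyond the scatter.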